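Swapping Ethoxy for Nitro: What to Expect

This account rests on a few compounds, and the source may have more. Where it says the series, first, only, none or still open, it means among the compounds named here.

Compound 1 `COc1cccc(OC)c1C(=O)/C=C/c1ccccc1` – 1150 nM
Compound 2 `CCOc1ccccc1C(=O)/C=C/c1ccccc1` – 609 nM

Within the data shown here, in a functional assay for inhibition, with Homo sapiens as the target (a lower number here means a stronger inhibitor, a higher number a weaker inhibitor), compound 2 gives 609 nM, the lower of only two numbers, yet its gap to compound 1 lies within the usual scatter. The two cannot really be told apart.

Compound 3 `O=C(/C=C/c1ccccc1)c1ccccc1[N+](=O)[O-]` keeps the shared core but has nitro in place of ethoxy on an aromatic carbon, ortho to a large group (nitro in place of ethoxy on an aromatic carbon). Among the measured compounds shown here, no measured compound carries a nitro group, and no measured step shows what such a swap does, so the expectation stays broad. A modest rise in the number in this assay is expected, meaning a somewhat weaker inhibitor, with the estimated change being a 1.5-fold higher number from compound 2 to compound 3 (0.17 log units; within the scatter) and possibly not much beyond the scatter. Compound 3 is estimated at 900 nM (expected range 200 nM to 4000 nM).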

Compound 3, half-maximal inhibitory concentration: 1520 nM
For compound 3 the middle estimate is 1.7-fold (0.23 log units) below the measured one, and the stated range covers the measured number.
By their numbers in this assay, from the lowest: compounds 2, 1 and 3 (each within the scatter of the next, the first and the last beyond it).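

In this assay, nitro in place of ethoxy on this aromatic carbon, ortho to a large group, gives a 2.5-fold higher number from compound 2 to compound 3 (0.40 log units; beyond the scatter). This step is modest, but it lies beyond the scatter, so the group at this position does affect the result, and the two groups are not interchangeable here, even with the same count of heavy atoms. Nothing available here bears on why the number rises.

Still open, on these data alone, is how this same carbon would respond to an amine or a carboxylic acid, which would help show whether the rise is specific to nitro or follows from losing ethoxy. A longer chain, such as butoxy, would test whether the number can fall below that of compound 2 at 609 nM.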